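The source may hold more compounds than are shown below. What is called first, only, known or untested is meant among the compounds shown, and "the series" means these compounds.

In a functional assay on NCI-H520 cells (Homo sapiens) for inhibition, read by MTT assay, with a stated time of 48 h, tested at 10 uM (on this read-out lower numbers stand for less inhibition and higher numbers for more inhibition at the one concentration tested (going by the name of the read-out)), the series runs from compound 1 `COc1cc(NC(=O)Nc2cc(Nc3ccc(F)c(Cl)c3)ncn2)cc(OC)c1`, which gives 25.5%, through compound 2 `COc1cc(NC(=O)Nc2cc(Nc3ccc(C)c(F)c3)ncn2)cc(OC)c1`, which gives 30.6%, to compound 3 `COc1cc(NC(=O)Nc2cc(Nc3cc(I)ccc3OC)ncn2)cc(OC)c1`, which gives 55%. Compound 3 holds the highest of the three numbers: the step of a number 29.5 percentage points higher from compound 1 to compound 3 (beyond the scatter) and the step of a number 24.4 percentage points higher from compound 2 to compound 3 (beyond the scatter) both lie beyond the scatter, whereas the step of a number 5.1 percentage points higher from compound 1 to compound 2 (within the scatter) stays within it. Compound 3 thus stands apart from the other two on the aryl carrying iodo and methoxy.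

Compound 4 `COc1cc(NC(=O)Nc2cc(Nc3cc(Br)ccc3OC)ncn2)cc(OC)c1` differs from compound 3 only in bromo in place of iodo on an aromatic carbon. Among the measured compounds shown here, no measured step bears directly on this change: the two steps that reach compound 3 exchange the whole aryl group rather than one halogen on it, and the one step that keeps the aryl pattern, a number 5.1 percentage points higher from compound 1 to compound 2 (within the scatter), is within the scatter, so the series gives no read on a halogen swap at a fixed place. Bromo enters exactly where iodo leaves, so the expectation in this assay is a small step, more likely downward than upward, and not clearly beyond the scatter. For compound 4 the estimated step is a number 7 percentage points lower from compound 3 to compound 4 (within the scatter), with an expected value of 48% in the range 30% to 65%.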

Compound 4, a percentage reported as inhibition, at one concentration (the size of the read-out at that concentration, not a potency): 43.5%
Estimate against measurement, compound 4: 4.5 percentage points above, within the range that was stated.
By their numbers in this assay, from the lowest: compounds 1 and 2 (each within the scatter of the next); then compound 4; then compound 3.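

Notes on the halogen at this place: this assay gives the first read on a single-atom exchange with the rest of the aryl fixed, and the step of a number 11.5 percentage points lower from compound 3 to compound 4 (beyond the scatter) shows that bromo in place of iodo, para to a methoxy group, is not neutral here. The 5-bromo-2-methoxyphenyl group still keeps clear of both earlier aryl groups, through the step of a number 12.9 percentage points higher from compound 2 to compound 4 (beyond the scatter) and the step of a number 18 percentage points higher from compound 1 to compound 4 (beyond the scatter) in turn, so the lead of this substitution pattern does not depend on iodo alone, although iodo adds to it within the four compounds. Nothing measured on these compounds explains why the exchange of the two halogens moves the number.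

The compounds shown leave open whether chloro, fluoro or plain hydrogen at the same place would continue the drop from iodo to bromo, or whether the halogen can give way to a methyl or a nitrile group. They also leave open how much of the lead belongs to the methoxy group itself, which a hydroxy or ethoxy group at that place on the 5-bromo-2-methoxyphenyl ring would test.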